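Swapping a Thiophene for a Phenyl on a Shared Core

The compounds below may be only part of what the source reports. "The series", "measured", "known", "first", "only" and "open" are said of these compounds alone.

Measured so far:
compound 1 `Oc1ccc(-c2cc(-c3cccc(Cl)c3)nc(-c3cccs3)c2)cc1`: 2720 nM
compound 2 `Oc1cccc(-c2cc(-c3cccc(Cl)c3)nc(-c3cccs3)c2)c1`: 3150 nM

In an ADME assay on HEK293 cells (Homo sapiens) for cytotoxicity, read by CCK-8 assay and cell counting, with a stated time of 2 days (a lower number here means a stronger inhibitor, a higher number a weaker inhibitor), compound 1 gives 2720 nM. Among the compounds with values here, its number is the smaller of the two measured, but the only measured step, a 1.2-fold higher number from compound 1 to compound 2 (0.06 log units; within the scatter), lies within the scatter, so the two compounds cannot be told apart on these numbers. That step moved the hydroxyl group on the hydroxyphenyl ring and left the rest of the shared core untouched.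

Compound 3 `Oc1ccc(-c2cc(-c3ccccc3)nc(-c3cccc(Cl)c3)c2)cc1` is the next candidate. It differs from compound 1 by phenyl in place of thiophen-2-yl on an aromatic carbon. Within the data shown here, no measured step touches this part of the core: the one step known concerns the hydroxyphenyl ring, not the five-membered ring. There is thus nothing in the data to suggest a shift in either direction, and the plain expectation is a step in this assay that stays within the scatter.

Compound 3 is therefore estimated at about 2700 nM, with a range from 1100 nM to 6500 nM. The step this estimate implies, a 1.0-fold lower number from compound 1 to compound 3 (0.00 log units; within the scatter), is expected to be within the scatter.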

Compound 3, half-maximal inhibitory concentration: 2820 nM
Compound 3: middle estimate off by 1.0-fold (0.02 log units), on the low side, and the stated range covers the measured number.
By their numbers in this assay, from the lowest: compounds 1, 3 and 2 (each within the scatter of the next).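

Within the data shown here, this is the first view of the group next to the ring nitrogen, and in this assay putting phenyl in place of thiophen-2-yl gives a 1.0-fold higher number from compound 1 to compound 3 (0.02 log units; within the scatter). A five-membered aromatic ring with a sulfur atom and a six-membered aromatic ring of carbon only therefore cannot be told apart at this position on these numbers, even though the two rings differ in both size and atom make-up. Nothing available explains why this exchange stays within the scatter.

From the compounds shown here alone, both groups tried at this position are aromatic rings, so it remains open whether something of a different kind in the same place, such as an amine like morpholine or a short alkyl chain, would stay within the scatter of compound 1 or move clear of it. Going by these compounds, the 3-chlorophenyl group is also the same in all three compounds, so the effect of changing it, for example by replacing the chlorine with a carboxylic acid, remains open too.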